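The source may hold more compounds than are shown below. What is called first, only, known or untested is meant among the compounds shown, and "the series" means these compounds.

Measured compounds in a functional assay on the whole organism with Rattus norvegicus as the target; on this read-out higher numbers stand for an effect only at larger amounts of compound and lower numbers for an effect already at smaller amounts:
compound 1 `Cc1nn(C)c2c1C(c1ccccc1Cl)=NCC(=O)N2` gives 16 mg/kg
compound 2 `CCCCn1nc(C)c2c1NC(=O)CN=C2c1ccccc1Cl` gives 32 mg/kg

Compound 2 carries the highest number of the two, the nearest being compound 1; the difference a 2.0-fold higher number from compound 1 to compound 2 (0.30 log units; within the scatter) lies within the scatter. Compound 3 `Cc1nn(C2CCCCC2)c2c1C(c1ccccc1Cl)=NCC(=O)N2` differs from compound 2 by cyclohexyl in place of butyl on an aromatic nitrogen. Among the measured compounds shown here, the only step on this nitrogen, hydrogen to butyl, is a 2.0-fold higher number from compound 1 to compound 2 (0.30 log units; within the scatter) and did not move the number beyond the scatter; nothing measured covers a ring group here. Compound 3 is therefore expected to stay near compound 2, with a step of no change at the digits printed from compound 2 to compound 3 (within the scatter). The estimate for compound 3 in this assay is 32 mg/kg, with a range from 12 mg/kg to 90 mg/kg.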

Compound 3, minimum effective dose: > 500 mg/kg
Compound 3: a limit, no number; the forecaster's own chance of this, stated with the estimate: 10%; middle value at least 15-fold (1.19 log units) from the limit.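

In this assay compound 3 gives > 500 mg/kg, which is a limit of the assay and not a number. The aromatic nitrogen is therefore sensitive to the group it carries: cyclohexyl in place of butyl gives an at least 15-fold higher number from compound 2 to compound 3 (1.19 log units; beyond the scatter) and cyclohexyl in place of methyl gives an at least 31-fold higher number from compound 1 to compound 3 (1.49 log units; beyond the scatter), whereas butyl in place of methyl stayed within the scatter at a 2.0-fold higher number from compound 1 to compound 2 (0.30 log units; within the scatter). Among these three compounds, only cyclohexyl separates from the others.

As far as these compounds go, it remains open whether the ring or the carbon count matters, which hexyl on this nitrogen would separate. From the compounds shown here alone, whether a smaller ring such as cyclopropyl behaves like cyclohexyl also stays open.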